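Acetamido in place of fluoro: an expected step

The source may hold more compounds than are shown below. What is called first, only, known or untested is meant among the compounds shown, and "the series" means these compounds.

Within the data shown here, in a functional assay on HepG2 cells (Homo sapiens) for cytotoxicity, read by MTT assay, with a stated time of 24 h (a lower number here means a stronger inhibitor, a higher number a weaker inhibitor), compound 1 `Cc1ccc(S(=O)(=O)N2C/C(=C\c3cccnc3)C(=O)/C(=C/c3ccccc3C(F)(F)F)C2)cc1` gives 2930 nM and compound 2 `O=C1/C(=C/c2cccnc2)CN(S(=O)(=O)c2ccc(F)cc2)C/C1=C\c1ccccc1C(F)(F)F` gives 2340 nM, so compound 2 stands level with its only measured neighbour. Compound 3 `CC(=O)Nc1ccc(S(=O)(=O)N2C/C(=C\c3cccnc3)C(=O)/C(=C/c3ccccc3C(F)(F)F)C2)cc1` carries acetamido in place of fluoro on an aromatic carbon, para to a large group: acetamido in place of fluoro on an aromatic carbon. Among the measured compounds shown here, the only measured step at that carbon is a 1.3-fold lower number from compound 1 to compound 2 (0.10 log units; within the scatter), and no measured step tests a group like acetamido. No change beyond the scatter is therefore expected, and the estimated step is a 1.2-fold higher number from compound 2 to compound 3 (0.08 log units; within the scatter). For compound 3 the expected value is 2800 nM, with an estimated range of 1100 nM to 7000 nM.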

Compound 3, half-maximal inhibitory concentration: 4330 nM
Compound 3: middle estimate off by 1.5-fold (0.19 log units), on the low side; measured number inside the range.
By their numbers in this assay, from the lowest: compounds 2, 1 and 3 (each within the scatter of the next).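

At this aromatic carbon, para to a large group, acetamido brings a hydrogen-bond donor and a hydrogen-bond acceptor, yet this assay gives a 1.9-fold higher number from compound 2 to compound 3 (0.27 log units; within the scatter) and a 1.5-fold higher number from compound 1 to compound 3 (0.17 log units; within the scatter) so that neither step leaves the scatter. The position therefore accepts acetamido, fluoro and methyl without a step beyond the scatter, a tolerance seen only across these three compounds. No supporting measurement bears on why these numbers stay so close. The compounds shown leave open whether an amine, a carboxylic acid or a longer chain at this carbon would give a step beyond the scatter.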